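The compounds below may be only part of what the source reports. "The series", "measured", "known", "first", "only" and "open" are said of these compounds alone.

Measured so far in an assay on RBL-1 cells for inhibition of Polyunsaturated fatty acid 5-lipoxygenase (Rattus norvegicus); a lower number here means a stronger inhibitor, a higher number a weaker inhibitor:

- compound 1 `O=C1NCCN(c2cccc(F)c2)N1`: 19000 nM
- compound 2 `CC1CN(c2cccc(F)c2)NC(=O)N1`: 6300 nM
- compound 3 `COc1cccc(N2CCNC(=O)N2)n1`: 9500 nM

Two cores are represented. Compound 1 and compound 2 share one; compound 3 carries the other, and the difference between the two cores is not broken down here. Within the first core, the only counted change is methyl in place of hydrogen on a saturated ring carbon, and it gave a 3.0-fold lower number from compound 1 to compound 2 (0.48 log units; beyond the scatter). The values of compound 3 and compound 2, and of compound 3 and compound 1, lie within the scatter of each other, so nothing about order is read from them.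

Compound 4 `COc1cccc(N2CC(C)NC(=O)N2)n1` is not yet measured. Against compound 3 it shows (methyl in place of hydrogen on a saturated ring carbon). The place is the same kind as in the earlier pair, except that the ring atom two ring bonds away bears a group of 8 heavy atoms rather than 7, so the change is the same kind of change, not the same. Among the measured compounds shown here, because the one measured instance gave a 3.0-fold lower number from compound 1 to compound 2 (0.48 log units; beyond the scatter), a step of similar size is expected, a 2.7-fold lower number from compound 3 to compound 4 (0.43 log units; beyond the scatter), resting on that single pair only. Compound 4 is therefore estimated at 3500 nM, within 1500 nM to 8500 nM.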

Compound 4, half-maximal inhibitory concentration: 5500 nM
Compound 4: middle estimate off by 1.6-fold (0.20 log units), on the low side, and the stated range covers the measured number.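

In this assay, methyl in place of hydrogen on a saturated ring carbon gives a 1.7-fold lower number from compound 3 to compound 4 (0.24 log units; within the scatter), a step that cannot be read as a change on its own. Set beside the earlier instance, it shows no difference in step size between the core of compound 1 and the core of compound 3 that stands clear of the scatter: the same change on two cores in this assay, a 3.0-fold lower number (0.48 log units; beyond the scatter) from compound 1 to compound 2 and a 1.7-fold lower number (0.24 log units; within the scatter) from compound 3 to compound 4, 1.7-fold (0.24 log units) apart, within the scatter of two such steps. This does not show that the step has the same size on both cores, nor that methyl lowers the number on the core of compound 3, and two pairs involving a single small group at one place make no rule for the series.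

Open, from the compounds shown here alone, is whether a longer chain such as ethyl or propyl at this saturated ring carbon, or an amine or a carboxylic acid there, would move the number further than methyl does. Also open, going by these compounds, is whether a methyl step of this kind would hold on a core carrying another aromatic substituent, such as chloro or trifluoromethyl.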